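The source may hold more compounds than are shown below. What is called first, only, known or untested is meant among the compounds shown, and "the series" means these compounds.

Among the compounds with values here, compound 1 `CCOC(=O)C1=Cc2ccccc2OC1(OCc1cn(CC(=O)Nc2ccc(C)cc2)nn1)C(F)(F)F` is one of two compounds measured in a functional assay on HeLa cells (Homo sapiens) for inhibition, read by MTT assay, with a stated time of 24 h (a lower number here means a stronger inhibitor, a higher number a weaker inhibitor), and in this assay compound 1 gives 67400 nM. Compound 2 `COc1ccc(-c2cc(COC3(C(F)(F)F)Oc4ccccc4C=C3C(=O)O)on2)cc1` stands at > 150000 nM in this assay, which is a limit of the assay rather than a number. The other value shown is therefore (the limit of > 150000 nM in this assay, at which 1 of the 2 values shown sits). Among the numbers shown, compound 1 holds the only real value. Compound 3 `CCOC(=O)C1=Cc2ccccc2OC1(OCc1cn(CC(=O)Nc2ccc(OC)cc2)nn1)C(F)(F)F` has not yet been measured in this assay. It differs from compound 1 in one place: methoxy in place of methyl on an aromatic carbon. Within the data shown here, no two measured compounds differ by this change alone, so nothing measured here shows what the exchange does. The expectation is that the step of a 1.0-fold higher number from compound 1 to compound 3 (0.02 log units; within the scatter) stays within the usual scatter of repeated measurements, in either direction. Compound 3 is therefore estimated at 70000 nM in this assay, with a plausible range from 25000 nM to 200000 nM.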

Compound 3, half-maximal inhibitory concentration: 31900 nM
Compound 3: middle estimate off by 2.2-fold (0.34 log units), on the high side; low and high end bracket the measured number.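

In this assay, within the data shown here, this is the first comparison across a single change: replacing methyl with methoxy on the aromatic ring, para to a large group, gives a 2.1-fold lower number from compound 1 to compound 3 (0.32 log units; beyond the scatter). The step is modest, but it shows that this position responds to a small change while the rest of the molecule stays the same, and that methoxy here gives the stronger inhibitor of the pair. Nothing measured bears on why the number moves.

The compounds shown leave open whether the number would keep falling with a longer chain such as ethoxy at this position, or would move the other way with an amine or a chlorine atom. They also leave open how a plain phenyl ring, with only hydrogen at this position, would compare with compound 1 and compound 3.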